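Fluoro-methylpyridinyl ether as the next permeability step

The compounds below may be only part of what the source reports. "The series", "measured", "known", "first", "only" and "open" are said of these compounds alone.

Three compounds share one core and differ only in the pyridinyl group carried on an oxygen on an aromatic ring. Compound 1 `Cn1c(COc2cccc(C(=O)O)c2)nc2ccc(Oc3cc(Cl)ccn3)cc21` gives 10.3 10^-6 cm/s in an ADME assay for permeability, using PAMPA, with a stated time of 4 h; a higher number here means that the compound crosses the layer faster, a lower number that the compound crosses the layer more slowly. Compound 2 `Cc1ccc(Oc2ccc3nc(COc4cccc(C(=O)O)c4)n(C)c3c2)nc1` gives 4.8 10^-6 cm/s, and compound 3 `Cc1ccc(C)c(Oc2ccc3nc(COc4cccc(C(=O)O)c4)n(C)c3c2)n1` gives 11 10^-6 cm/s. Compound 3 and compound 1 lie within the scatter of each other, as a 1.1-fold higher number from compound 1 to compound 3 (0.03 log units; within the scatter) shows, while a 2.3-fold higher number from compound 2 to compound 3 (0.36 log units; beyond the scatter) and a 2.1-fold lower number from compound 1 to compound 2 (0.33 log units; beyond the scatter) are modest steps beyond it. Compound 4 `Cc1cc(F)cnc1Oc1ccc2nc(COc3cccc(C(=O)O)c3)n(C)c2c1` carries 5-fluoro-3-methylpyridin-2-yl in place of 3,6-dimethylpyridin-2-yl on an oxygen on an aromatic ring. The two steps that bear on this are a 2.3-fold higher number from compound 2 to compound 3 (0.36 log units; beyond the scatter) and a 1.1-fold higher number from compound 1 to compound 3 (0.03 log units; within the scatter), both small or absent. Compound 4 is therefore expected to show a 1.4-fold lower number from compound 3 to compound 4 (0.14 log units; within the scatter), a drift toward the lower side but not beyond the scatter. Compound 4 is estimated at 8 10^-6 cm/s, between 4.5 10^-6 cm/s and 14 10^-6 cm/s.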

Compound 4, apparent permeability: 8.3 10^-6 cm/s
For compound 4 the middle estimate is 1.0-fold (0.02 log units) below the measured one, within the range that was stated.
By their numbers in this assay, from the lowest: compounds 2, 4, 1 and 3 (each within the scatter of the next, the first and the last beyond it).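

Replacing 3,6-dimethylpyridin-2-yl with 5-fluoro-3-methylpyridin-2-yl on an oxygen on an aromatic ring gives a 1.3-fold lower number from compound 3 to compound 4 (0.12 log units; within the scatter) in this assay, and the other readings are a 1.2-fold lower number from compound 1 to compound 4 (0.09 log units; within the scatter) and a 1.7-fold higher number from compound 2 to compound 4 (0.24 log units; within the scatter). Compound 2 and compound 3 lie beyond the scatter of each other, yet compound 4 lies within the scatter of both, so this fluorinated group adds no separate level at this position. Nothing available here explains this result.

The compounds leave open whether a pyridinyl group carrying an amine or a nitrile would also stay within this range.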